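A few compounds are considered here, and "the series" means these few. Any claim that something is new, unique, unknown or untested is made for them only; others in the source may bear on it.

Compound 1 `CCCCCCNc1nc(SCc2ccc(C(F)(F)F)cc2)nc2ccccc12` is the starting point. For the measured compounds named here, in a functional assay on MDA-MB-231 cells (Homo sapiens) for cytotoxicity, read by MTT assay, with a stated time of 72 h (a higher number here means a weaker inhibitor, a lower number a stronger inhibitor), compound 1 gives 20200 nM, the only plain number among the two values shown. Compound 2 `CCCCCCCCCCCCCCNc1nc(SCc2ccc(C(F)(F)F)cc2)nc2ccccc12` carries a longer chain on the same nitrogen. In this assay compound 2 reaches only a limit of the assay, > 50000 nM, and no number. The step of an at least 2.4-fold higher number from compound 1 to compound 2 (0.39 log units; beyond the scatter) came with octyl in place of hydrogen on a saturated chain carbon, six bonds along the chain from a nitrogen on an aromatic ring; of the two values shown, one sits at the limit of > 50000 nM in this assay, at which 1 of the 2 values shown sits.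

Compound 3 `FC(F)(F)c1ccc(CSc2nc(Nc3ccccc3)c3ccccc3n2)cc1` differs from compound 1 as follows: phenyl in place of hexyl on a nitrogen on an aromatic ring. The group on that nitrogen changes from hexylamino to anilino, while the shared core is unchanged. Going by the values given here, the only measured step, the lengthening of the chain, weakened the inhibitor at least modestly, but it does not compare a chain with a ring, so nothing measured speaks directly to this change. Compound 3 is therefore expected to sit close to compound 1, with an estimated step of a 1.0-fold lower number from compound 1 to compound 3 (0.00 log units; within the scatter) in this assay, within the scatter. The estimate for compound 3 is 20000 nM, expected to fall between 7000 nM and 50000 nM.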

Compound 3, half-maximal inhibitory concentration: 18400 nM
Compound 3: the middle estimate sits 1.1-fold (0.04 log units) above what was measured; low and high end bracket the measured number.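

In this assay the change from hexyl to phenyl on a nitrogen on an aromatic ring comes with a 1.1-fold lower number from compound 1 to compound 3 (0.04 log units; within the scatter) and so makes no readable difference. The earlier step compared only two chains, whereas this one shows that an aromatic ring with the same number of heavy atoms as the hexyl chain can stand on this nitrogen without a measurable change in the cell result. It gives no size for the loss seen with the longer chain because compound 2 reaches only a limit of the assay: the limit of > 50000 nM in this assay, at which 1 of the 3 values shown sits.

Still open, from the compounds shown here alone, is how this nitrogen responds to a much shorter chain such as butyl, or to a phenyl ring that itself carries a hydroxyl group or an amine. Also open is what happens away from this nitrogen, where the trifluoromethyl group stays the same in all the compounds shown, for instance with a nitrile in its place.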